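Aryl amide change from compound 2 to compound 3

A few compounds are considered here, and "the series" means these few. Any claim that something is new, unique, unknown or untested is made for them only; others in the source may bear on it.

In a functional assay on MCF7 cells (Homo sapiens) for inhibition, read by MTT assay, with a stated time of 72 h (a lower number here means a stronger inhibitor, a higher number a weaker inhibitor), compound 1 `CCCCc1ccc(NC(=O)C2CCN(C/C=C/c3ccccc3)CC2)cc1` gives 5870 nM as a measured number. Compound 2 `COc1ccc(NC(=O)C2CCN(C/C=C/c3ccccc3)CC2)cc1` gives > 100000 nM as a limit of the assay and not a number. Compound 2 therefore stands at the limit of > 100000 nM in this assay, at which 1 of the 2 values shown sits, without an exact position. Compound 3 `O=C(Nc1ccc(F)c(Br)c1)C1CCN(C/C=C/c2ccccc2)CC1` differs from compound 2 by 3-bromo-4-fluorophenyl in place of 4-methoxyphenyl on an amide-type nitrogen on the same core. Among the compounds with values here, the only measured step is an at least 17-fold higher number from compound 1 to compound 2 (1.23 log units; beyond the scatter) for methoxy in place of butyl on an aromatic carbon, so a sizeable move toward a lower number is expected in this assay here. The expected step is an at least 6.6-fold lower number from compound 2 to compound 3 (0.82 log units; beyond the scatter) on this estimate. For compound 3 the estimated value is 15000 nM with an expected range from 3000 nM to 70000 nM in this assay.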

Compound 3, half-maximal inhibitory concentration: 13500 nM
Compound 3: the middle estimate sits 1.1-fold (0.05 log units) above what was measured; the range from low to high includes it.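

In this assay the 3-bromo-4-fluorophenyl in place of 4-methoxyphenyl on the amide-type nitrogen gives an at least 7.4-fold lower number from compound 2 to compound 3 (0.86 log units; beyond the scatter) on the same core, so the aryl group at this position decides whether a measured value is reached at all. A measurable value here is not confined to the butyl group of compound 1. As far as these compounds go, compound 2 holds a limit and not a number, so the full size of the step stays unknown: the limit of > 100000 nM in this assay, at which 1 of the 3 values shown sits.

Bromine and fluorine enter together, and neither is seen alone. From the compounds shown here alone, whether an amine or a carboxylic acid on this aryl ring would keep a measurable value also stays open.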